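Series notes: nitro in place of bromo, compound 3 to compound 4

The compounds below may be only part of what the source reports. "The series", "measured", "known", "first", "only" and "open" are said of these compounds alone.

Among the measured compounds shown here, compound 3 `COc1ccc(C(=O)/C=C/c2ccc(Br)cc2)c2c1C=CC(C)(C)O2` is one of three compounds measured in a functional assay on HCT-116 cells (Homo sapiens) for antiproliferative activity, read by MTT assay, with a stated time of 24 h; a higher number here means a weaker inhibitor, a lower number a stronger inhibitor. In this assay compound 3 gives only a limit, > 10000 nM. Compound 1 `COc1cccc(/C=C/C(=O)c2ccc(OC)c3c2OC(C)(C)C=C3)c1` likewise returns a limit, > 10000 nM. Compound 2 `COc1ccc(C(=O)/C=C/c2cccc(F)c2)c2c1C=CC(C)(C)O2` also returns a limit, > 10000 nM. Every value shown sits at the limit of > 10000 nM in this assay, at which 3 of the 3 values shown sit, so the steps a step that the two limits leave unreadable from compound 1 to compound 2, a step that the two limits leave unreadable from compound 1 to compound 3 and a step that the two limits leave unreadable from compound 2 to compound 3 carry no readable size. Compound 4 `COc1ccc(C(=O)/C=C/c2ccc([N+](=O)[O-])cc2)c2c1C=CC(C)(C)O2` carries nitro in place of bromo on an aromatic carbon. For the measured compounds named here, no measured step bears on this change, and the measured steps set no size in either direction, so nothing beyond the scatter can be drawn from them. The step that the limit leaves unreadable from compound 3 to compound 4 is expected to be small. Compound 4 is expected to give 15000 nM in this assay, within 5000 nM to 50000 nM, most likely again as a limit.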

Compound 4, half-maximal inhibitory concentration: 8880 nM
Estimate against measurement, compound 4: 1.7-fold (0.23 log units) above, and the stated range covers the measured number.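

In this assay compound 4 is the only entry that reads as a number and not as a limit: the limit of > 10000 nM in this assay, at which 3 of the 4 values shown sit. Nitro in place of bromo, para to a large group, gives an at least 1.1-fold lower number from compound 3 to compound 4 (0.05 log units; that floor lies within the scatter), the first step at this position with a readable floor. The other two steps to the 4-nitrophenyl compound carry the same floor: an at least 1.1-fold lower number from compound 2 to compound 4 (0.05 log units; that floor lies within the scatter) and an at least 1.1-fold lower number from compound 1 to compound 4 (0.05 log units; that floor lies within the scatter).

As far as these compounds go, the true size of each step stays open, and the steps among compounds 1, 2 and 3 cannot be read. From the compounds shown here alone, how an amine or a carboxylic acid at the same place would read also remains open.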